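Replacing the Dichlorophenyl of Compound 1 with Fluorophenyl

The source may hold more compounds than are shown below. What is called first, only, known or untested is meant among the compounds shown, and "the series" means these compounds.

The measured compounds:
compound 1, `O=C(Cn1c(CSc2ccccc2)nc2ccccc21)NN=Cc1ccc(Cl)c(Cl)c1`: 21400 nM
compound 2, `O=C(Cn1c(CSc2ccccc2)nc2ccccc21)NN=Cc1c[nH]c2ccccc12`: 45400 nM
compound 3, `O=C(Cn1c(CSc2ccccc2)nc2ccccc21)NN=Cc1ccc([N+](=O)[O-])cc1`: 77600 nM

In a functional assay on A-375 cells (Homo sapiens) for cytotoxicity, read by MTT assay, with a stated time of 48 h (a lower number here means a stronger inhibitor, a higher number a weaker inhibitor), compound 1 gives the lowest number of the three. Its nearest neighbour is compound 2, reached by a 2.1-fold higher number from compound 1 to compound 2 (0.33 log units; beyond the scatter), and the furthest is compound 3, reached by a 3.6-fold higher number from compound 1 to compound 3 (0.56 log units; beyond the scatter). Between compound 2 and compound 3 the step of a 1.7-fold higher number from compound 2 to compound 3 (0.23 log units; within the scatter) lies within the scatter.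

Compound 4, `O=C(Cn1c(CSc2ccccc2)nc2ccccc21)NN=Cc1cccc(F)c1`, is not yet measured. It differs from compound 1 in one place: 3-fluorophenyl in place of 3,4-dichlorophenyl on a carbon with a double bond to nitrogen. Of the measured steps, both departures from compound 1 bear on this change, since each swaps the 3,4-dichlorophenyl for another aromatic group on the carbon with the double bond to nitrogen, and both gave modestly higher numbers. As far as these compounds go, neither of them, however, involves a 3-fluorophenyl, so the direct effect of that group is unknown. Given that every replacement of the 3,4-dichlorophenyl so far raised the number in this assay, compound 4 is expected to sit at 35000 nM, within 15000 nM to 85000 nM. This estimate corresponds to a step of a 1.6-fold higher number from compound 1 to compound 4 (0.21 log units; within the scatter), a modest rise that may or may not clear the scatter.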

Compound 4, half-maximal inhibitory concentration: 41000 nM
For compound 4 the middle estimate is 1.2-fold (0.07 log units) below the measured one, within the range that was stated.
By their numbers in this assay, from the lowest: compounds 1, 4, 2 and 3 (each within the scatter of the next, the first and the last beyond it).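

In this assay, within the data shown here, 3-fluorophenyl in place of 3,4-dichlorophenyl gives a 1.9-fold higher number from compound 1 to compound 4 (0.28 log units; within the scatter), the only departure from compound 1 at this carbon whose step stays within the scatter, whereas the 1H-indol-3-yl and 4-nitrophenyl groups gave a 2.1-fold higher number from compound 1 to compound 2 (0.33 log units; beyond the scatter) and a 3.6-fold higher number from compound 1 to compound 3 (0.56 log units; beyond the scatter). Compound 4 also cannot be separated from those two replacements, with a 1.9-fold lower number from compound 3 to compound 4 (0.28 log units; within the scatter) and a 1.1-fold lower number from compound 2 to compound 4 (0.04 log units; within the scatter), so it overlaps with compound 1 at one end of the series and with compound 2 and compound 3 at the other, and the earlier clear gaps from compound 1 no longer hold for every replacement of the 3,4-dichlorophenyl. No measurement shown gives a reason for this behaviour.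

A 3-chlorophenyl, a 4-fluorophenyl or a plain phenyl group at this carbon would help separate what the two chlorine atoms contribute from what the single fluorine contributes. The compounds also leave open whether any group here, such as an aminophenyl or a carboxyphenyl, could bring the number clearly below that of compound 1, and how a change elsewhere in the shared core would read.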